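Flavone Cytotoxicity: A Larger Substituent on the Shared Core

This account rests on a few compounds, and the source may have more. Where it says the series, first, only, none or still open, it means among the compounds named here.

Measured compounds:
compound 1 `CCc1c(F)c(N)c2c(=O)cc(-c3ccc(N)c(F)c3)oc2c1F`, 130 nM
compound 2 `COc1c(F)c(N)c2c(=O)cc(-c3ccc(N)c(F)c3)oc2c1F`, 100 nM
compound 3 `Nc1ccc(-c2cc(=O)c3c(N)c(F)c(Cl)c(F)c3o2)cc1F`, 210 nM

In a functional assay on MCF7 cells (Homo sapiens) for cytotoxicity, read by neutral red uptake, with a stated time of 3 days (a lower number here means a stronger inhibitor, a higher number a weaker inhibitor), compound 2 gives the lowest of the three numbers, though its distance from compound 1 is a 1.3-fold lower number from compound 1 to compound 2 (0.11 log units; within the scatter), within the scatter, while compound 3 stands a 2.1-fold higher number from compound 2 to compound 3 (0.32 log units; beyond the scatter) away. Compound 4 `CCCCCC(=O)NCc1c(F)c(N)c2c(=O)cc(-c3ccc(N)c(F)c3)oc2c1F` differs from compound 2 by ((pentylcarbonyl)amino)methyl in place of methoxy on an aromatic carbon. The measured steps at this carbon all involve small groups: a 1.3-fold lower number from compound 1 to compound 2 (0.11 log units; within the scatter), a 1.6-fold higher number from compound 1 to compound 3 (0.21 log units; within the scatter) and a 2.1-fold higher number from compound 2 to compound 3 (0.32 log units; beyond the scatter); none speaks to a chain of this length. The three small groups changed the number little, so the expected step of a 3.0-fold higher number from compound 2 to compound 4 (0.48 log units; beyond the scatter) is a modest rise with wide uncertainty. Compound 4 is thus estimated at 300 nM, between 80 nM and 1500 nM.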

Compound 4, half-maximal inhibitory concentration: 340 nM
Estimate against measurement, compound 4: 1.1-fold (0.05 log units) below; measured number inside the range.
By their numbers in this assay, from the lowest: compounds 2, 1, 3 and 4 (each within the scatter of the next, the first and the last beyond it).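

In this assay this carbon accepts the ((pentylcarbonyl)amino)methyl group, of 9 heavy atoms, with only modest steps: a 3.4-fold higher number from compound 2 to compound 4 (0.53 log units; beyond the scatter) against methoxy and a 2.6-fold higher number from compound 1 to compound 4 (0.42 log units; beyond the scatter) against ethyl. Against chloro, the step is a 1.6-fold higher number from compound 3 to compound 4 (0.21 log units; within the scatter) and so does not separate the long chain from that small group. No measurement at hand bears on why the number rises. The compounds shown leave open whether chain length or the amide carries these steps: an aminomethyl group or a shorter acetamide chain would separate the two.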